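Series notes: swap on the ring amine nitrogen, compound 2 to 3

The source may report more compounds than this note shows. Statements on the series, on what has been measured and on what is new or still open speak of the compounds shown alone.

Two compounds have numbers in an assay on isolated protein for inhibition of Nicotinamide phosphoribosyltransferase (Homo sapiens), read by mass spectrometry, with stated times of 15 min and 30 min; a lower number here means a stronger inhibitor, a higher number a weaker inhibitor. Compound 1 `O=C(NCc1ccc(S(=O)(=O)C2CCC(F)(F)CC2)cc1)N1Cc2ccncc2C1` gives 78 nM in this assay. Compound 2 `CC(=O)N1CCC(S(=O)(=O)c2ccc(CNC(=O)N3Cc4ccncc4C3)cc2)CC1` gives 83 nM in this assay; of the two numbers it is the higher one, but the step of a 1.1-fold higher number from compound 1 to compound 2 (0.03 log units; within the scatter) lies within the scatter, so the two compounds are not separated.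

Compound 3 `O=C(NCc1ccc(S(=O)(=O)C2CCN(C3COC3)CC2)cc1)N1Cc2ccncc2C1` has not been measured. Relative to compound 2 the difference is oxetan-3-yl in place of acetyl on an amine nitrogen in a ring; cut one bond further out, it reads 1-acetylpiperidin-4-yl to 1-(oxetan-3-yl)piperidin-4-yl. Within the data shown here, no measured step touches this nitrogen directly. Among the measured compounds shown here, the only step available, a 1.1-fold higher number from compound 1 to compound 2 (0.03 log units; within the scatter), exchanged the whole group on the sulfonyl sulfur and did not move the number beyond the scatter, which points to this part of compound 2 accepting change without a clear shift. A step of about a 1.0-fold lower number from compound 2 to compound 3 (0.02 log units; within the scatter) is therefore expected, none beyond the scatter. Compound 3 is estimated at 80 nM in this assay, with a range from 30 nM to 250 nM.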

Compound 3, half-maximal inhibitory concentration: 31 nM
Estimate against measurement, compound 3: 2.6-fold (0.41 log units) above; the range from low to high includes it.
By their numbers in this assay, from the lowest: compound 3; then compounds 1 and 2 (each within the scatter of the next).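

In this assay, the substituent on the ring amine nitrogen of the six-membered ring can move the number: oxetan-3-yl in place of acetyl gives a step beyond the scatter (a 2.7-fold lower number from compound 2 to compound 3 (0.43 log units; beyond the scatter)). The exchange at the sulfonyl sulfur now also separates compounds: 1-(oxetan-3-yl)piperidin-4-yl in place of 4,4-difluorocyclohexyl gives a modest step (a 2.5-fold lower number from compound 1 to compound 3 (0.40 log units; beyond the scatter)), while 1-acetylpiperidin-4-yl in that place stayed within the scatter (a 1.1-fold higher number from compound 1 to compound 2 (0.03 log units; within the scatter)). Nothing available accounts for the shift.

From the compounds shown here alone, it remains open whether the unsubstituted ring amine or a simple methyl on this nitrogen would read with compound 3 or with compound 2. Also open, going by these compounds, is whether a larger ring, such as tetrahydropyran-4-yl, would keep the step seen with oxetan-3-yl.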